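The compounds below may be only part of what the source reports. "The series", "measured", "known", "first", "only" and "open" are said of these compounds alone.

In a functional assay (blood) for inhibition, with Homo sapiens as the target (on this read-out higher numbers stand for weaker inhibition and lower numbers for stronger inhibition), compound 1 `CC(C)(C)Sc1c(CC(C)(C)C(=O)O)n(Cc2ccc(Cl)cc2)c2ccc(OCc3cc4ccccc4cn3)cc12` gives > 3000 nM, which is a limit of the assay and not a number. Compound 2 `CC(C)(C)Sc1c(CC(C)(C)C(=O)O)n(Cc2ccc(Cl)cc2)c2ccc(OCc3cccnc3)cc12` gives > 3000 nM, which is also a limit. Compound 2 thus has no number of its own and stands at the limit of > 3000 nM in this assay, at which 2 of the 2 values shown sit. Among the measured compounds shown here, the only measured step is a step that the two limits leave unreadable from compound 1 to compound 2, so it offers no size to carry forward. Compound 3 `C[C@@H](COc1ccc2c(c1)c(SC(C)(C)C)c(CC(C)(C)C(=O)O)n2Cc1ccc(Cl)cc1)c1ccccn1` differs from compound 2 at one place: 1-(pyridin-2-yl)ethyl in place of pyridin-3-yl on a saturated chain carbon bound to an oxygen on an aromatic ring. There, 1-(pyridin-2-yl)ethyl stands in place of pyridin-3-yl on a saturated chain carbon bound to an oxygen on an aromatic ring, and it brings 1 defined stereocentre. With no readable step to go on, no firm direction can be expected in this assay. The expected step, an at least 1.2-fold lower number from compound 2 to compound 3 (0.07 log units; that floor lies within the scatter), is therefore only a rough estimate. For compound 3 the estimated value is 2500 nM, with an expected range from 700 nM to 8000 nM.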

Compound 3, half-maximal inhibitory concentration: 280 nM
The estimate for compound 3 lay 8.9-fold (0.95 log units) above the measured number; the whole stated range lies above it.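

In this assay, this position on a saturated chain carbon bound to an oxygen on an aromatic ring proves able to move the read-out off its limit: 1-(pyridin-2-yl)ethyl in place of pyridin-3-yl gives an at least 10-fold lower number from compound 2 to compound 3 (1.02 log units; beyond the scatter). Set against isoquinolin-3-yl, the same group gives an at least 10-fold lower number from compound 1 to compound 3 (1.02 log units; beyond the scatter). The step between the two earlier groups cannot be read, and only 1-(pyridin-2-yl)ethyl yields a number rather than a limit: the limit of > 3000 nM in this assay, at which 2 of the 3 values shown sit.

The change brings a different ring attachment, more chain carbons and a defined stereocentre together, and the compounds shown do not separate these. Going by these compounds, it stays open whether a plain pyridin-2-yl, a 1-phenylethyl or the mirror-image 1-(pyridin-2-yl)ethyl would give a number of the same order at this place.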